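Two Cyanobenzyl Groups on the Amine of Compound 2

A few compounds are considered here, and "the series" means these few. Any claim that something is new, unique, unknown or untested is made for them only; others in the source may bear on it.

Measured so far:
Compound 1, `O=C([C@@H]1C[C@H](NS(=O)(=O)c2ccccc2)CN1)N1CCSC1`: in an assay on a cell-free system (plasma) for inhibition of Dipeptidyl peptidase 4 (Rattus norvegicus), read by fluorescence (on this read-out lower numbers stand for stronger inhibition and higher numbers for weaker inhibition), compound 1 gives > 300 nM, which is a limit of the assay and not a number.
Compound 2, `CN(Cc1ccc(C#N)cc1)[C@@H]1CN[C@H](C(=O)N2CCSC2)C1`: in this assay compound 2 gives 13.6 nM.

Compound 2 stands as the only compound with a numbered result in this assay; the other result shown is the limit of > 300 nM in this assay, at which 1 of the 2 values shown sits. Going by the values given here, compound 1 and compound 2 differ in more than one place, so no single step is counted between them, and nothing beyond their two values can be said of that pair.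

Compound 3, `N#Cc1ccc(CN(Cc2ccc(C#N)cc2)[C@@H]2CN[C@H](C(=O)N3CCSC3)C2)cc1`, differs from compound 2 by 4-cyanophenyl in place of hydrogen on a saturated chain carbon bound to an amine nitrogen; cut one bond further out, the change reads methyl to 4-cyanobenzyl, so the amine nitrogen of compound 3 carries two 4-cyanobenzyl groups. Among the compounds with values here, no measured step covers a change of this kind, and the expectation rests on compound 2 alone. The step is expected to be small and toward weaker inhibition, a 2.9-fold higher number from compound 2 to compound 3 (0.47 log units; beyond the scatter), with a result inside the scatter of compound 2 well possible. Compound 3 is accordingly estimated at 40 nM, between 10 nM and 200 nM.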

Compound 3, half-maximal inhibitory concentration: 9.3 nM
Compound 3: the middle estimate sits 4.3-fold (0.63 log units) above what was measured; measured number outside the range, below it.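

Putting 4-cyanobenzyl in place of methyl on the amine nitrogen, so that this nitrogen carries two such groups, gives a 1.5-fold lower number from compound 2 to compound 3 (0.17 log units; within the scatter). Going by these compounds alone, until now, the only number in this assay belonged to a compound with a small methyl at this place; the new pair shows that this place, the saturated chain carbon bound to an amine nitrogen, takes a 4-cyanophenyl group of 8 heavy atoms, with its six-membered aromatic ring and its nitrile, and inhibition stays within the scatter. Nothing shown bears on why the larger group is accepted here.

The compounds shown do not tell whether the nitrile on the added ring matters, as a plain benzyl group or a benzyl group carrying a carboxylic acid at that place would be needed to separate the ring from its substituent. They also leave open how far this tolerance extends, for instance to a longer chain such as phenylethyl on the same nitrogen, or to a bare hydrogen in place of the methyl of compound 2.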